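The compounds below may be only part of what the source reports. "The series", "measured", "known", "first", "only" and "open" are said of these compounds alone.

The series shares one core, seen in compound 1 `COc1cc(/C=C/c2ccc(NC(=O)/C=C/c3ccc(OC)c(OC)c3)cc2)cc(OC)c1`. In a functional assay on MDA-MB-231 cells (Homo sapiens) for inhibition, read by MTT assay, with a stated time of 48 h (on this read-out higher numbers stand for weaker inhibition and lower numbers for stronger inhibition), compound 1 gives 7740 nM, the lower of the two numbers recorded so far. Its nearest neighbour is compound 2 `COc1cc(/C=C/c2ccc(NC(=O)/C=C/c3ccc([N+](=O)[O-])cc3)cc2)cc(OC)c1`, which in this assay gives 11700 nM. Among the compounds with values here, the single step separating the pair, a 1.5-fold higher number from compound 1 to compound 2 (0.18 log units; within the scatter), exchanges the 3,4-dimethoxyphenyl for 4-nitrophenyl and stays within the scatter, so the two values cannot be ordered.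

Compound 3 `COc1cc(/C=C/c2ccc(NC(=O)/C=C/c3ccc(F)cc3)cc2)cc(OC)c1` is the next variation at the same position: 4-fluorophenyl in place of 3,4-dimethoxyphenyl on a double-bonded chain carbon bound to a double-bonded chain carbon. Within the data shown here, the only measured step that bears on this change is a 1.5-fold higher number from compound 1 to compound 2 (0.18 log units; within the scatter), where the same 3,4-dimethoxyphenyl on the same double-bonded chain carbon was exchanged for 4-nitrophenyl and the number stayed within the scatter. Among the measured compounds shown here, with only that precedent, no step beyond the scatter is expected in this assay for compound 3, in either direction. The step expected for compound 3 is a 1.2-fold higher number from compound 1 to compound 3 (0.07 log units; within the scatter). Compound 3 is therefore estimated at 9000 nM in this assay. The expected range for compound 3 runs from 4000 nM to 20000 nM.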

Compound 3, half-maximal inhibitory concentration: 9390 nM
Beside the measured number, compound 3's estimate is 1.0-fold (0.02 log units) below it, within the range that was stated.
By their numbers in this assay, from the lowest: compounds 1, 3 and 2 (each within the scatter of the next).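

In this assay the step of a 1.2-fold higher number from compound 1 to compound 3 (0.08 log units; within the scatter) takes out 3,4-dimethoxyphenyl, with 10 heavy atoms and 2 hydrogen-bond acceptors, and puts in 4-fluorophenyl, with 7 heavy atoms and 0 hydrogen-bond acceptors, yet the number stays within the scatter. The second step of a 1.2-fold lower number from compound 2 to compound 3 (0.10 log units; within the scatter) exchanges nitro for fluoro on an aromatic carbon and also stays within the scatter, so this assay does not separate any of the three aryl groups tested on the double-bonded chain carbon. Within the data shown here, the position has now taken three differently substituted phenyl groups without a step beyond the scatter, which is more than the single earlier pair could show, and no measurement on hand offers an explanation for this.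

Still open, on these data alone, is whether a phenyl group carrying an amine or a carboxylic acid, or a longer chain in place of the phenyl group, would move the number beyond the scatter at this position. As far as these compounds go, it is also open whether any change elsewhere on the shared core, such as at the amide hydrogen, would do so.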